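Furan substituent removal in the nicotinic series

The compounds below may be only part of what the source reports. "The series", "measured", "known", "first", "only" and "open" are said of these compounds alone.

Compound 1 `Oc1c(C2=NC3(CN2)CN2CCC3CC2)oc2ccccc12` carries a hydroxy on an aromatic carbon of the shared core, and in an assay on cell membranes for displacement of a labelled ligand from Neuronal acetylcholine receptor; alpha4/beta2 (Rattus norvegicus), read by scintillation counting, with a stated time of 2 h, tested at 5 uM (a higher number here means more inhibition at the concentration tested (going by the name of the read-out), a lower number less inhibition), compound 1 gives 32%. Going by the values given here, compound 2 `Nc1c(C2=NC3(CN2)CN2CCC3CC2)oc2ccccc12` has an amino on that same carbon, and in this assay compound 2 gives 9%, the lowest of the two numbers so far, with compound 1 the nearest at the higher reading. Among the compounds with values here, the single measured step, a number 23 percentage points lower from compound 1 to compound 2 (beyond the scatter), shows that changing the group at this position shifts the read-out by a modest amount, beyond the scatter. Compound 3 `c1ccc2oc(C3=NC4(CN3)CN3CCC4CC3)cc2c1` removes the group altogether: hydrogen in place of amino on an aromatic carbon. Within the data shown here, no measured step covers loss of the amino, so the direction is open; the hydroxy-to-amino step only indicates that this position influences the reading. Compound 3 is therefore expected to fall between the two measured readings, near 20%, with a range from 5% to 45%. The step this implies is expected to be a number 11 percentage points higher from compound 2 to compound 3 (beyond the scatter).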

Compound 3, a percentage reported as inhibition, at one concentration (the size of the read-out at that concentration, not a potency): 4%
Beside the measured number, compound 3's estimate is 16 percentage points above it; the whole stated range lies above it.
By their numbers in this assay, from the lowest: compounds 3 and 2 (each within the scatter of the next); then compound 1.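

In this assay the amino proves to add nothing that can be read at this position: a number 5 percentage points lower from compound 2 to compound 3 (within the scatter), so amino and hydrogen on this aromatic carbon cannot be told apart. The hydroxy alone stands apart from the other two, with a number 28 percentage points lower from compound 1 to compound 3 (beyond the scatter), which shows that the gap seen in the earlier step belongs to the hydroxy and is not a general effect of having any group on this carbon. Nothing at hand bears on why the hydroxy differs.

On these data alone, whether the reading of compound 1 needs the hydroxy itself remains open, and a methoxy on the same carbon would test whether another oxygen-linked group holds it. A chlorine or a methyl there would show whether the low readings extend to groups without oxygen or nitrogen.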